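The compounds below may be only part of what the source reports. "The series", "measured", "known", "first", "only" and "open" are said of these compounds alone.

Compound 1 `CC(O)(CSc1ccc(S(F)(F)(F)(F)F)cc1)C(=O)Nc1ccc(C#N)c(C(F)(F)F)c1` gives 18100 nM
Compound 2 `CC(O)(CSc1ccc(S(F)(F)(F)(F)F)cc1)C(=O)Nc1ccc([N+](=O)[O-])c(C(F)(F)F)c1` gives 9200 nM
Compound 3 `CC(O)(CSc1ccc(S(F)(F)(F)(F)F)cc1)C(=O)Nc1ccc(C#N)cc1C(F)(F)F` gives 13200 nM

All three compounds were tested in a functional assay on CWR22R cells (Homo sapiens) for antiproliferative activity, read by propidium iodide staining, with a stated time of 96 h; a higher number here means a weaker inhibitor, a lower number a stronger inhibitor. There, compound 3 at 13200 nM lies within the scatter of both compound 1 and compound 2, so the three values do not separate from one another.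

The next compound, compound 4 `CC(O)(CSc1ccc(S(F)(F)(F)(F)F)cc1)C(=O)Nc1ccc([N+](=O)[O-])cc1C(F)(F)F`, has nitro in place of cyano on an aromatic carbon of compound 3: nitro in place of cyano on an aromatic carbon. The same exchange has been measured once, and that single step bears directly on this one: a 2.0-fold lower number from compound 1 to compound 2 (0.29 log units; within the scatter). That step stays within the scatter, and the two pairs differ in where the trifluoromethyl group stands, so it offers only weak guidance. In this assay, a small shift toward a lower number is therefore expected, if any shift can be seen at all. The expected change is a 1.5-fold lower number from compound 3 to compound 4 (0.17 log units; within the scatter), which would not stand clear of the scatter. For compound 4 the estimated value is 9000 nM, with an expected range from 5000 nM to 16000 nM.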

Compound 4, half-maximal inhibitory concentration: 13100 nM
For compound 4 the middle estimate is 1.5-fold (0.16 log units) below the measured one; measured number inside the range.
By their numbers in this assay, from the lowest: compounds 2, 4, 3 and 1 (each within the scatter of the next).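

In this assay, nitro in place of cyano on the aromatic carbon meta to a trifluoromethyl group gives a 1.0-fold lower number from compound 3 to compound 4 (0.00 log units; within the scatter). The exchange can now be read on two cores, and neither reading stands clear of the scatter, nor do the two readings stand clear of each other: the same change on two cores in this assay, a 2.0-fold lower number (0.29 log units; within the scatter) from compound 1 to compound 2 and a 1.0-fold lower number (0.00 log units; within the scatter) from compound 3 to compound 4, 2.0-fold (0.29 log units) apart, within the scatter of two such steps. On these four compounds, this exchange therefore has no effect that can be read on either core, and the place of the trifluoromethyl group cannot be said to alter the outcome.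

The compounds shown leave open whether a different group on this aromatic carbon, such as an amine or a carboxylic acid, would give a value that stands clear of the scatter. They also leave open whether cyano and nitro would separate on a core carrying another group in place of trifluoromethyl.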